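From a hydrazine end group to an aryl-bearing chain

A few compounds are considered here, and "the series" means these few. Any claim that something is new, unique, unknown or untested is made for them only; others in the source may bear on it.

Compound 1, `CC1=CC[C@@H]([C@@](C)(O)CCCC(C)(C)NC=S)CC1`, in a functional assay on NCI-H460 cells (Homo sapiens) for cytotoxicity, read by sulforhodamine B assay (on this read-out lower numbers stand for stronger inhibition of growth and higher numbers for weaker inhibition of growth), gives > 100000 nM, which is a limit of the assay.
Compound 2, `CC1=CC[C@@H]([C@@](C)(O)CCCC(C)(C)NC(=S)NN)CC1`, in this assay gives 84000 nM.

Compound 2 therefore holds the only numerical result in this assay; the other result is a limit, (the limit of > 100000 nM in this assay, at which 1 of the 2 values shown sits). Among the compounds with values here, the single measured step, an at least 1.1-fold lower number from compound 1 to compound 2 (0.07 log units; that floor lies within the scatter), starts from that limit, so its true size cannot be pinned down. Compound 3, `CC1=CC[C@@H]([C@@](C)(O)CCCC(C)(C)NC(=S)N/N=C\c2ccccc2)CC1`, differs from compound 2 by a group of 8 heavy atoms (7 carbon, 1 nitrogen; one six-membered aromatic ring of carbon only) in place of one nitrogen atom, on an amide-type nitrogen. Within the data shown here, no measured step covers a change of this kind; the only measured step, an at least 1.1-fold lower number from compound 1 to compound 2 (0.07 log units; that floor lies within the scatter), concerns the same nitrogen-bearing end of the molecule but is too small to point in any firm direction. With so little to go on, a moderate lowering of the number is expected for compound 3 rather than none, a step of a 2.8-fold lower number from compound 2 to compound 3 (0.45 log units; beyond the scatter), though the uncertainty is wide. Compound 3 is accordingly estimated at 30000 nM in this assay, with a likely range from 5000 nM to 100000 nM.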

Compound 3, concentration for total growth inhibition: > 100000 nM
Compound 3 gave a limit, no number; the forecaster's own chance of this, stated with the estimate: 20%; middle value at least 3.3-fold (0.52 log units) away from the limit.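

In this assay, putting a group of 8 heavy atoms with a six-membered aromatic ring on the amide-type nitrogen, in place of the amino nitrogen of compound 2, gives an at least 1.1-fold higher number from compound 2 to compound 3 (0.07 log units; that floor lies within the scatter). Within the data shown here, this step is only a floor, so its true size is unknown, but it shows that this large aromatic group does not bring the moderate lowering of the number that a first step on this end of the molecule might have suggested. Compound 3 now joins compound 1 as a limit rather than a number, and the step between these two limits cannot be read: the limit of > 100000 nM in this assay, at which 2 of the 3 values shown sit.

Among these compounds, compound 2 remains the only compound here with a numerical result, so no trend can be drawn for this nitrogen-bearing end of the molecule. As far as these compounds go, it remains open whether a methyl group on the same nitrogen, a pyridine ring in place of the six-membered carbon ring, or a carboxylic acid on that ring would keep the number of compound 2, lower it, or take it back to the limit.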